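A few compounds are considered here, and "the series" means these few. Any claim that something is new, unique, unknown or untested is made for them only; others in the source may bear on it.

Among the compounds with values here, compound 2 `COc1c(C)c(O)c(C)c(O)c1C(=O)/C=C/c1ccccc1` gives 7720 nM in an ADME assay on MDCK cells (Canis lupus familiaris) for cytotoxicity, read by neutral red uptake, with a stated time of 48 h (a higher number here means that more compound is needed for the effect, a lower number that less compound is needed), the highest of the two numbers so far. Compound 1 `COc1c(C)c(O)c(C)c(O)c1C(=O)/C=C/c1ccc(O)cc1` gives 4900 nM, and the step of a 1.6-fold higher number from compound 1 to compound 2 (0.20 log units; within the scatter) shows that a hydrogen in place of hydroxy on an aromatic carbon stayed within the scatter. Compound 3 `COc1c(C)c(O)c(C)c(O)c1C(=O)/C=C/c1ccccc1O` differs from compound 2 by hydroxy in place of hydrogen on an aromatic carbon. Within the data shown here, the only measured step that bears on this, a hydroxy–hydrogen exchange on the same ring, was a 1.6-fold higher number from compound 1 to compound 2 (0.20 log units; within the scatter), so in this assay no step beyond the scatter is expected for this second hydroxy. For compound 3 the expected step is a 1.3-fold lower number from compound 2 to compound 3 (0.11 log units; within the scatter), giving an estimate of 6000 nM (range 3000 nM to 12000 nM).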

Compound 3, half-maximal effective concentration: 8790 nM
Estimate against measurement, compound 3: 1.5-fold (0.17 log units) below; the measured number falls inside the stated range.
By their numbers in this assay, from the lowest: compounds 1, 2 and 3 (each within the scatter of the next).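

In this assay, hydroxy placed ortho to a large group gives a 1.1-fold higher number from compound 2 to compound 3 (0.06 log units; within the scatter), so this position, like the earlier hydroxy exchange, shows no step beyond the scatter. Shifting the hydroxy, 2-hydroxyphenyl in place of 4-hydroxyphenyl, also stays flat, at a 1.8-fold higher number from compound 1 to compound 3 (0.25 log units; within the scatter). No evidence on the reason for these small steps is available. On these data alone, whether an amine, a carboxylic acid or a methoxy group on this ring would give a step beyond the scatter remains open.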